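The source may report more compounds than this note shows. Statements on the series, on what has been measured and on what is new or still open speak of the compounds shown alone.

Working notes on the series.

Compound 2 `COc1ccc(-c2cc3c(cn2)[nH]c(=O)n3-c2cc(OC)c(OC)c(OC)c2)cc1` gives 1210 nM in a functional assay on HeLa cells (Homo sapiens) for antiproliferative activity, read by MTT assay, with a stated time of 48 h; on this read-out higher numbers stand for weaker inhibition and lower numbers for stronger inhibition. Compound 3 `COc1ccc(-c2cc3c(cn2)[nH]c(=O)n3-c2cc(OC)c(OC)c(OC)c2)cc1F` differs by fluoro in place of hydrogen on an aromatic carbon and gives 2210 nM in this assay; the step of a 1.8-fold higher number from compound 2 to compound 3 (0.26 log units; within the scatter) lies within the scatter, so the two numbers are not distinguished. Among the measured compounds shown here, compound 1 `COc1ccc(-c2cncc3[nH]c(=O)n(Cc4cc(OC)c(OC)c(OC)c4)c23)cc1O` carries the hydroxy-methoxyphenyl on a different core and gives > 20000 nM in this assay, which is a limit of the assay and not a number (the limit of > 20000 nM in this assay, at which 1 of the 3 values shown sits); no single step connects compound 1 to the other two.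

Compound 4 `COc1ccc(-c2cc3c(cn2)[nH]c(=O)n3-c2cc(OC)c(OC)c(OC)c2)cc1O` is to be measured in this assay. It differs from compound 3 as hydroxy in place of fluoro on an aromatic carbon. For the measured compounds named here, the only measured step, from compound 2 to compound 3, concerns the same aromatic carbon and stayed within the scatter; no step tests hydroxy in place of fluoro directly. The expectation is therefore a step of a 1.5-fold lower number from compound 3 to compound 4 (0.17 log units; within the scatter) of about the same size, not clearly beyond the scatter. Compound 4 is estimated at 1500 nM in this assay, with a range of 400 nM to 6000 nM.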

Compound 4, half-maximal inhibitory concentration: 490 nM
The estimate for compound 4 lay 3.1-fold (0.49 log units) above the measured number, within the range that was stated.
By their numbers in this assay, from the lowest: compound 4; then compounds 2 and 3 (each within the scatter of the next). At a limit, above all of these: compound 1.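

Hydroxy on this aromatic carbon, ortho to a methoxy group, gives in this assay both a 4.5-fold lower number from compound 3 to compound 4 (0.65 log units; beyond the scatter) and a 2.5-fold lower number from compound 2 to compound 4 (0.39 log units; beyond the scatter) as modest steps. The position therefore responds to what it carries, which the fluoro step alone did not show, since hydrogen and fluoro stay within the scatter of each other while hydroxy stands apart from both. Nothing measured in the series accounts for this difference.

Whether the lower number depends on the hydroxy itself stays open, since a methoxy, an amine or a carboxylic acid on this carbon lies outside the compounds shown. Compound 1 carries the 3-hydroxy-4-methoxyphenyl on a different core and gives > 20000 nM as a limit of the assay and not a number, so the effect of this change on that core cannot be read.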